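Changing the aryl substituent: methylsulfanyl to bromomethyl

The source may hold more compounds than are shown below. What is called first, only, known or untested is meant among the compounds shown, and "the series" means these compounds.

Measured so far in a functional assay on KBVIN cells (Homo sapiens) for antiproliferative activity, read by sulforhodamine B assay, with a stated time of 3 days (on this read-out lower numbers stand for an effect already at smaller amounts and higher numbers for an effect only at larger amounts of compound), as follows
- compound 1 `CCC1=C(O)c2c(oc(-c3ccc(O)cc3)cc2=O)C(CC)(CC)C1=O` gives 20.6 uM
- compound 2 `CCC1=C(O)c2c(oc(-c3ccc(OC)cc3)cc2=O)C(CC)(CC)C1=O` gives 0.68 uM
- compound 3 `CCC1=C(O)c2c(oc(-c3ccc(SC)cc3)cc2=O)C(CC)(CC)C1=O` gives 1.38 uM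

Compound 3 holds the second highest of the three numbers and stands between compound 2 and compound 1. The change to compound 4 `CCC1=C(O)c2c(oc(-c3ccc(CBr)cc3)cc2=O)C(CC)(CC)C1=O` puts bromomethyl in place of methylsulfanyl on an aromatic carbon para to a large group, and bromomethyl in place of methylsulfanyl on an aromatic carbon gives the count. Among the compounds with values here, no measured step involves bromomethyl. Replacing hydroxy gave large steps, a 30-fold lower number from compound 1 to compound 2 (1.48 log units; beyond the scatter) and a 15-fold lower number from compound 1 to compound 3 (1.17 log units; beyond the scatter) in size. Compound 4 also lacks that hydroxy, so it is expected to stay near compound 3 on the evidence of the modest 2.0-fold higher number from compound 2 to compound 3 (0.31 log units; beyond the scatter) between the two groups without it. The estimated step is a 1.1-fold higher number from compound 3 to compound 4 (0.04 log units; within the scatter) and none beyond the scatter is expected in this assay here. For compound 4 the estimated value is 1.5 uM with an expected range from 0.5 uM to 6 uM in this series.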

Compound 4, concentration for half-maximal effect: 27.9 uM
For compound 4 the middle estimate is 19-fold (1.27 log units) below the measured one; the whole stated range lies below it.
By their numbers in this assay, from the lowest: compound 2; then compound 3; then compounds 1 and 4 (each within the scatter of the next).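

In this assay the absence of hydroxy does not by itself keep the number low at this position: bromomethyl gives a 20-fold higher number from compound 3 to compound 4 (1.31 log units; beyond the scatter) and also a 41-fold higher number from compound 2 to compound 4 (1.61 log units; beyond the scatter) here. With a 1.4-fold higher number from compound 1 to compound 4 (0.13 log units; within the scatter) on the same position, bromomethyl stands level with hydroxy, so methoxy and methylsulfanyl do not speak for every group lacking that hydroxy. Nothing available here accounts for this result.

Open, on these data alone, is whether a plain methyl or a chloromethyl stays with compound 4 or returns towards compound 2. Also open, as far as these compounds go, is where an amine or a carboxylic acid at this position would fall.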